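Bromo on the pyridinyl ether of compound 3

The source may report more compounds than this note shows. Statements on the series, on what has been measured and on what is new or still open speak of the compounds shown alone.

Compound 3 `COc1nc(C)c(Nc2nc(Cl)cn([C@H](COc3ccccn3)C3CC3)c2=O)cc1C` gives the lowest number of the three measured in an assay on frontal cortex for displacement of a labelled ligand from corticotropin-releasing factor receptor 1 (Rattus norvegicus), with a stated time of 2 h (on this read-out lower numbers stand for stronger inhibition and higher numbers for weaker inhibition), at 1.2 nM. Compound 1 `COc1nc(C)c(Nc2nc(Cl)cn([C@H](COC(=O)Nc3cccc(C#N)c3)C3CC3)c2=O)cc1C` stands closest: in this assay compound 1 gives 1.3 nM, and a 1.1-fold lower number from compound 1 to compound 3 (0.03 log units; within the scatter), so the two are not distinguishable. Compound 2 `CCCNC(=O)OC[C@H](C1CC1)n1cc(Cl)nc(Nc2cc(C)c(OC)nc2C)c1=O` sits apart: in this assay compound 2 gives 10 nM; both an 8.3-fold lower number from compound 2 to compound 3 (0.92 log units; beyond the scatter) and a 7.7-fold higher number from compound 1 to compound 2 (0.89 log units; beyond the scatter) exceed the scatter. Compound 4 `COc1nc(C)c(Nc2nc(Cl)cn([C@H](COc3cc(Br)ccn3)C3CC3)c2=O)cc1C` differs from compound 3 in one place: bromo in place of hydrogen on an aromatic carbon. Among the compounds with values here, none of the measured steps touch this ring; all three concern what replaces the carbamate or pyridinyl group on the oxygen, and they show only that the pyridinyl ether and the aryl carbamate are interchangeable there, while the propyl carbamate of compound 2 costs. Within the data shown here, no measured compound carries a substituent on the pyridinyl ring, so the step to compound 4 has no direct precedent. Compound 4 is therefore expected to land near compound 3 in this assay. The step of a 1.3-fold higher number from compound 3 to compound 4 (0.10 log units; within the scatter) is expected to stay within the scatter. The estimate for compound 4 in this assay is 1.5 nM, with a range from 0.5 nM to 5 nM.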

Compound 4, half-maximal inhibitory concentration: 1.5 nM
The estimate for compound 4 equals the measured number at the digits printed; the range from low to high includes it.
By their numbers in this assay, from the lowest: compounds 3, 1 and 4 (each within the scatter of the next); then compound 2.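

In this assay, within the data shown here, the pyridinyl ring carries a substituent for the first time, and the aromatic carbon opposite the ring nitrogen accepts a bromo: a 1.3-fold higher number from compound 3 to compound 4 (0.10 log units; within the scatter) is the whole effect of the change. The 4-bromopyridin-2-yl ether also keeps the standing of the pyridin-2-yl ether against both carbamates, as a 1.2-fold higher number from compound 1 to compound 4 (0.06 log units; within the scatter) leaves it level with the (3-cyanophenyl)carbamoyl group and a 6.7-fold lower number from compound 2 to compound 4 (0.82 log units; beyond the scatter) keeps it clear of the propylcarbamoyl group. Nothing at hand bears on why this carbon accepts the bromo.

A single bromo does not tell how an amine, a carboxylic acid or a longer chain would fare on this carbon. On these data alone, whether the other carbons of the ring accept a bromo also stays open.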